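The compounds below may be only part of what the source reports. "The series", "measured", "known", "first", "only" and "open" are said of these compounds alone.

Of the compounds shown here, three have been measured in a functional assay on the whole organism (Tail, strain ICR) with Mus musculus as the target, in the tail flick test, with a stated time of 150 min, at a dose of 25 umol/kg by the oral route; a higher number here means a stronger effect of the compound at the dose given, a lower number a weaker effect. Compound 1 `O=C(O)[C@@H]1CCCN1C(=O)CN(c1nc(Cl)nc2[nH]cnc12)C1CC1` gives 7.29%, compound 2 `O=C(OCc1ccccc1)[C@@H]1CCCN1C(=O)CN(c1nc(Cl)nc2[nH]cnc12)C1CC1` gives 31.1%, and compound 3 `CC(C)C[C@H](NC(=O)CN(c1nc(Cl)nc2[nH]cnc12)C1CC1)C(=O)OCc1ccccc1` gives 5.26%. Compound 3 and compound 1 lie within the scatter of each other; the difference between the cores of compound 3 and compound 2 is not broken down here. From compound 2 to compound 1 the change is hydrogen in place of benzyl on an oxygen next to a carbonyl group, and in this assay it gave a number 23.8 percentage points lower from compound 2 to compound 1 (beyond the scatter). Compound 4 `CC(C)C[C@H](NC(=O)CN(c1nc(Cl)nc2[nH]cnc12)C1CC1)C(=O)O`, not yet measured, carries the same change from compound 3: hydrogen in place of benzyl on an oxygen next to a carbonyl group. In this assay the expected step is a number 2.3 percentage points lower from compound 3 to compound 4 (within the scatter), clearly smaller than the earlier one because compound 3 already gives 5.26% and little room remains downward. Compound 4 is expected at about 3%, with a range from 0% to 12%.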

Compound 4, a percentage reported as activity, at one dose (the size of the read-out at that dose, not a potency): 9.13%
Compound 4: the middle estimate sits 6.1 percentage points below what was measured, within the range that was stated.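

Hydrogen in place of benzyl on an oxygen next to a carbonyl group gives a number 3.9 percentage points higher from compound 3 to compound 4 (within the scatter) in this assay, and the step does not carry over unchanged between the two cores: the same change on two cores in this assay, a number 23.8 percentage points lower (beyond the scatter) from compound 2 to compound 1 and a number 3.9 percentage points higher (within the scatter) from compound 3 to compound 4, 27.7 percentage points apart, beyond the scatter of two such steps

The drop seen on the core of compound 2 therefore cannot be used as a general rule for this change across the series. Two cores do not show which feature of the core sets the difference, nor how the change would behave on a third core.

Still open, as far as these compounds go, is how a methyl ester or a primary amide would compare with benzyloxycarbonyl and carboxy on these cores. From the compounds shown here alone, the effect of a longer chain in place of the chain of compound 4 also remains open.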